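What Happens When Methoxy Becomes Hydroxy?

The compounds below may be only part of what the source reports. "The series", "measured", "known", "first", "only" and "open" are said of these compounds alone.

In a functional assay on MCF7 cells (Homo sapiens) for cytotoxicity (on this read-out higher numbers stand for weaker inhibition and lower numbers for stronger inhibition), compound 1 `C=C/C=C\[C@H](C)[C@H](OC(N)=O)[C@@H](C)[C@H](O)[C@@H](C)C/C(C)=C\[C@H](C)[C@@H](O)[C@@H](C)/C=C\CCc1ccc(C)c(O)c1` gives 4000 nM on the shared core. Compound 2 `C=C/C=C\[C@H](C)[C@H](OC(N)=O)[C@@H](C)[C@H](O)[C@@H](C)C/C(C)=C\[C@H](C)[C@@H](O)[C@@H](C)/C=C\CCc1cccc(Cl)c1` gives 650 nM and compound 3 `C=C/C=C\[C@H](C)[C@H](OC(N)=O)[C@@H](C)[C@H](O)[C@@H](C)C/C(C)=C\[C@H](C)[C@@H](O)[C@@H](C)/C=C\CCc1cccc(OC)c1` gives 500 nM in the same test. Compound 3 sits with compound 2 at the low end of these three numbers, and the two cannot be told apart (a 1.3-fold lower number from compound 2 to compound 3 (0.11 log units; within the scatter)).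

Compound 4 `C=C/C=C\[C@H](C)[C@H](OC(N)=O)[C@@H](C)[C@H](O)[C@@H](C)C/C(C)=C\[C@H](C)[C@@H](O)[C@@H](C)/C=C\CCc1cccc(O)c1` differs from compound 3 by one small edit: hydrogen in place of methyl on an oxygen on an aromatic ring. This turns 3-methoxyphenyl into 3-hydroxyphenyl.

Going by the values given here, no measured step makes exactly this change. Among the compounds with values here, the closest evidence is compound 1, the only tested compound with a hydroxy on its aromatic ring, although that ring also carries a methyl. Replacing that ring gave beyond-scatter steps of modest size, both with the methoxy ring (an 8.0-fold lower number from compound 1 to compound 3 (0.90 log units; beyond the scatter)) and with the chloro ring (a 6.2-fold lower number from compound 1 to compound 2 (0.79 log units; beyond the scatter)). Compound 4 is therefore expected to shift part of the way towards compound 1, and the missing ring methyl leaves the size uncertain. The expected step is a 2.6-fold higher number from compound 3 to compound 4 (0.41 log units; beyond the scatter) in this assay as a modest rise. Compound 4 is estimated at 1300 nM (expected range 400 nM to 4500 nM).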

Compound 4, half-maximal inhibitory concentration: 390 nM
For compound 4 the middle estimate is 3.3-fold (0.52 log units) above the measured one, and the stated range ends above it.
By their numbers in this assay, from the lowest: compounds 4, 3 and 2 (each within the scatter of the next); then compound 1.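

In this assay, hydrogen in place of methyl on the oxygen of the aromatic ring makes no readable difference (a 1.3-fold lower number from compound 3 to compound 4 (0.11 log units; within the scatter)), so 3-hydroxyphenyl and 3-methoxyphenyl cannot be told apart on the shared core. The same holds when hydroxy stands in place of chloro on the aromatic carbon (a 1.7-fold lower number from compound 2 to compound 4 (0.22 log units; within the scatter)), so among compounds 2, 3 and 4, the three groups tried on this ring carbon give numbers within the usual scatter of one another. Going by these compounds alone, the large step lies elsewhere, with hydrogen in place of the ring methyl of compound 1 (a 10-fold lower number from compound 1 to compound 4 (1.01 log units; beyond the scatter)), which shows that the high number of compound 1 goes with that methyl and not with the hydroxy alone, something the earlier compounds could not separate.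

Nothing in the data given explains why one ring methyl weighs so much here when the swap of methoxy for hydroxy does not. From the compounds shown here alone, it also stays open whether an amine or a carboxylic acid on the same ring carbon would fit with hydroxy, methoxy and chloro, and whether a methyl added to the ring of compound 3 would raise the number as it does for the hydroxy ring.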